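Replacing the difluoropiperidine on the acetamide arm of compound 3

A few compounds are considered here, and "the series" means these few. Any claim that something is new, unique, unknown or untested is made for them only; others in the source may bear on it.

Compound 3 `C[C@@H]1CN(c2sc(C(F)(F)F)nc2-c2nc3ccccc3[nH]2)CCN1C(=O)CN1CCC(F)(F)CC1` was tested in a functional assay on CHO-K1 cells for antagonist activity at C-X-C chemokine receptor type 3 (Homo sapiens), read by FLIPR, with a stated time of 10 min, in the presence of a further agent that is not named here (on this read-out higher numbers stand for weaker inhibition and lower numbers for stronger inhibition), and gave 15 nM, the second highest of the three numbers recorded here. Compound 1 `C[C@@H]1CN(c2sc(C(F)(F)F)nc2-c2nc3ccccc3[nH]2)CCN1C(=O)Cn1ccc(C(=O)O)n1` gave 2100 nM, and compound 2 `Cc1nc(C)n(CC(=O)N2CCN(c3sc(C(F)(F)F)nc3-c3nc4ccc(C5CCOCC5)cc4[nH]3)C[C@H]2C)n1`, which carries a further group elsewhere on the shared core, gave 3.3 nM. Going by the values given here, the one measured step that bears on the position in question is a 140-fold lower number from compound 1 to compound 3 (2.15 log units; beyond the scatter), so this site clearly tolerates large swings.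

Compound 4 `Cc1nc(C)n(CC(=O)N2CCN(c3sc(C(F)(F)F)nc3-c3nc4ccccc4[nH]3)C[C@H]2C)n1` differs from compound 3 by 3,5-dimethyl-1H-1,2,4-triazol-1-yl in place of 4,4-difluoropiperidin-1-yl on a saturated chain carbon bound to a carbonyl carbon. The same entering group is present in compound 2, whose number sits well below that of compound 3, though compound 2 also differs from compound 4 at another site, so their two values can only be set side by side. On that basis compound 4 is expected to show a moderate step to a lower number, a 2.1-fold lower number from compound 3 to compound 4 (0.33 log units; beyond the scatter), landing near compound 2. The estimate for compound 4 is 7 nM, with a range from 2.5 nM to 25 nM.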

Compound 4, half-maximal inhibitory concentration: 3.2 nM
Compound 4: middle estimate off by 2.2-fold (0.34 log units), on the high side, within the range that was stated.
By their numbers in this assay, from the lowest: compounds 4 and 2 (each within the scatter of the next); then compound 3; then compound 1.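

In this assay, the 3,5-dimethyl-1H-1,2,4-triazol-1-yl on the saturated chain carbon bound to a carbonyl carbon outperforms both groups seen there earlier: it improves on the 4,4-difluoropiperidin-1-yl (a 4.7-fold lower number from compound 3 to compound 4 (0.67 log units; beyond the scatter)) and far more on the 3-carboxy-1H-pyrazol-1-yl (a 660-fold lower number from compound 1 to compound 4 (2.82 log units; beyond the scatter)). This extends the range at this position beyond what the earlier step had shown. With this triazole in place, hydrogen and oxan-4-yl on the aromatic carbon cannot be told apart (a 1.0-fold lower number from compound 2 to compound 4 (0.01 log units; within the scatter)), so the low number of compound 2 needs no contribution from the oxan-4-yl.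

The compounds shown do not separate the contribution of the two methyl groups from that of the triazole ring, a question that a plain 1H-1,2,4-triazol-1-yl or a 3,5-dimethyl-1H-pyrazol-1-yl on the same carbon would address. No measurement given here accounts for these differences.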